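From 2-Hydroxyphenyl to 3-Methoxyphenyl

The source may hold more compounds than are shown below. What is called first, only, known or untested is meant among the compounds shown, and "the series" means these compounds.

For the measured compounds named here, in a functional assay on LoVo cells (Homo sapiens) for inhibition, read by MTT assay, with a stated time of 24 h (a lower number here means a stronger inhibitor, a higher number a weaker inhibitor), compound 2 (`CC1(C)[C@H]2CC[C@]1(C)N(Cc1cn(-c3ccccc3O)nn1)C(=O)C2`) gives 540 nM as the higher of the two numbers so far, while compound 1 (`CC1(C)[C@H]2CC[C@]1(C)N(Cc1cn(-c3ccccc3C#N)nn1)C(=O)C2`) gives 140 nM as the lower. Compound 3 (`COc1cccc(-n2cc(CN3C(=O)C[C@@H]4CC[C@@]3(C)C4(C)C)nn2)c1`) has 3-methoxyphenyl in place of 2-hydroxyphenyl on an aromatic nitrogen. Going by the values given here, only one measured step bears on this change, and only loosely: hydroxy in place of cyano on an aromatic carbon, a modest move (a 3.9-fold higher number from compound 1 to compound 2 (0.59 log units; beyond the scatter)). The expected step (a 1.4-fold lower number from compound 2 to compound 3 (0.13 log units; within the scatter)) is smaller than that one, and its direction is uncertain. Compound 3 is estimated at 400 nM (from 130 nM to 1200 nM).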

Compound 3, half-maximal inhibitory concentration: 80 nM
For compound 3 the middle estimate is 5.0-fold (0.70 log units) above the measured one; the whole stated range lies above it.
By their numbers in this assay, from the lowest: compounds 3 and 1 (each within the scatter of the next); then compound 2.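

In this assay, the group on this aromatic nitrogen clearly matters: 3-methoxyphenyl in place of 2-hydroxyphenyl gives a step beyond the scatter (a 6.8-fold lower number from compound 2 to compound 3 (0.83 log units; beyond the scatter)). Set against 2-cyanophenyl, the same group stays within the scatter (a 1.8-fold lower number from compound 1 to compound 3 (0.24 log units; within the scatter)), so the nitrile is not the only group compatible with a low number here.

On these data alone, whether the methoxy itself or its different place on the phenyl ring produces the step stays open, since the two changes come together. As far as these compounds go, how an amine or a carboxylic acid on that ring would read is also open. Nothing available explains the step.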